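Cyclohexyl to phenyl beside the amide chain carbon

The compounds below may be only part of what the source reports. "The series", "measured", "known", "first", "only" and "open" are said of these compounds alone.

Compound 1 `O=C(NCC1CCCCC1)c1cccc(/C=C2\CC(=O)N(c3ccccc3)C2=O)c1` was examined in an ADME assay on HCT-116 cells (Homo sapiens) for cytotoxicity, read by MTT assay, with a stated time of 72 h; on this read-out lower numbers stand for stronger inhibition and higher numbers for weaker inhibition. In this assay compound 1 gives > 100000 nM, which is a limit of the assay and not a number. Compound 2 `CCCCCN1C(=O)C/C(=C\c2cccc(C(=O)Nc3cccc(CC)c3)c2)C1=O` gives 75300 nM in this assay. Compound 3 `O=C(Nc1ccc(Cl)cc1)c1cccc(/C=C2\CC(=O)N(Cc3ccccc3)C2=O)c1` gives > 100000 nM in this assay, again a limit. Compound 1 therefore stands at the limit of > 100000 nM in this assay, at which 2 of the 3 values shown sit, with no number beneath it. Compound 4 `O=C(NCc1ccccc1)c1cccc(/C=C2\CC(=O)N(c3ccccc3)C2=O)c1` differs from compound 1 by phenyl in place of cyclohexyl on a saturated chain carbon bound to an amide-type nitrogen. Going by the values given here, no measured pair differs in exactly this way, so no step of known size exists. Because compound 1 sits at the limit of > 100000 nM in this assay, at which 2 of the 3 values shown sit, only a value beneath that limit could reveal a step at all. The step of a number no higher from compound 1 to compound 4 (the limit leaves the size open) is expected to stay within the scatter. Compound 4 is estimated at 100000 nM, with a range from 50000 nM to 300000 nM.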

Compound 4, half-maximal inhibitory concentration: > 100000 nM
Compound 4: a limit, no number (the forecaster's own chance of this, stated with the estimate: 70%); the middle value sits exactly at the limit.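

Compound 1 and compound 4 both give limits of the assay in this assay, not numbers, so no step between them can be read: the limit of > 100000 nM in this assay, at which 3 of the 4 values shown sit.

The compounds shown leave open whether phenyl in place of cyclohexyl on a saturated chain carbon bound to an amide-type nitrogen changes the read-out at all.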